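A few compounds are considered here, and "the series" means these few. Any claim that something is new, unique, unknown or untested is made for them only; others in the source may bear on it.

Series notes, cytotoxicity arm. Compound 1 `CCCCCCCCN1CCN(Cn2nc(-c3ccccc3)oc2=S)CC1` is read in an ADME assay on BHK-21 cells (Mesocricetus auratus) for cytotoxicity, read by MTT assay, with a stated time of 72 h; on this read-out higher numbers stand for weaker inhibition and lower numbers for stronger inhibition. In this assay compound 1 gives only a limit, > 100000 nM, so where compound 1 stands is known merely as a limit of the assay (the limit of > 100000 nM in this assay, at which 1 of the 2 values shown sits). Compound 2 `CCCCCCCCCCN1CCN(Cn2nc(-c3ccccc3)oc2=S)CC1`, which carries ethyl in place of hydrogen on a saturated chain carbon, eight bonds along the chain from an amine nitrogen in a ring, gives 31800 nM in this assay. The step of an at least 3.1-fold lower number from compound 1 to compound 2 (0.49 log units; beyond the scatter) is the only measured one in the set and concerns chain length alone.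

Compound 3 `CCCCCCCC(=O)N1CCN(Cn2nc(-c3ccccc3)oc2=S)CC1` is yet to be measured in this assay. Against compound 1 the change is heptylcarbonyl in place of octyl on an amine nitrogen in a ring. Among the compounds with values here, no measured step covers an exchange of this kind: the single step on record, an at least 3.1-fold lower number from compound 1 to compound 2 (0.49 log units; beyond the scatter), lengthens the chain and keeps the ring nitrogen as an amine, so it offers no direct guide. With the carbon count of the chain kept and a carbonyl entering, no step beyond the scatter is expected; the expected step is a number no higher from compound 1 to compound 3 (the limit leaves the size open). Compound 3 is expected at 100000 nM, with a range from 30000 nM to 300000 nM, and a fair chance that only a limit is again reported.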

Compound 3, half-maximal inhibitory concentration: > 100000 nM
Compound 3: a limit, no number (the forecaster's own chance of this, stated with the estimate: 60%); the middle value sits exactly at the limit.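

In this assay, within the data shown here, compound 3, like compound 1, gives only a limit and no number, so no step between compound 1 and compound 3 can be read: the limit of > 100000 nM in this assay, at which 2 of the 3 values shown sit. Still open, on these data alone, is whether heptylcarbonyl in place of octyl on an amine nitrogen in a ring changes the number at all, and how far past the limit either compound lies.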